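From 3-aminophenyl to 2-bromophenyl on a sulfonyl sulfur

The source may report more compounds than this note shows. Statements on the series, on what has been measured and on what is new or still open speak of the compounds shown alone.

Compound 1 `Cc1noc(C)c1S(=O)(=O)N1CCC(N2CCC(C)CC2)CC1`: > 10000 nM
Compound 2 `CC1CCN(C2CCN(S(=O)(=O)c3cccnc3Cl)CC2)CC1`: > 10000 nM
Compound 3 `CC1CCN(C2CCN(S(=O)(=O)c3cccc(N)c3)CC2)CC1`: > 5000 nM

All three entries come from an ADME assay on HCT-116 cells (Homo sapiens) for cytotoxicity, read by CellTiter-Glo, with a stated time of 72 h (on this read-out lower numbers stand for stronger inhibition and higher numbers for weaker inhibition), and each is a limit of the assay, not a number. Compound 1 and compound 2 sit at one limit, (the limit of > 10000 nM in this assay, at which 2 of the 3 values shown sit). Compound 3 sits at another, (the limit of > 5000 nM in this assay, at which 1 of the 3 values shown sits), so its place on the scale is known only as a limit.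

The next compound to be read is compound 4 `CC1CCN(C2CCN(S(=O)(=O)c3ccccc3Br)CC2)CC1`. It carries 2-bromophenyl in place of 3-aminophenyl on a sulfonyl sulfur.

The measured steps that bear on this change all alter the same group on that sulfur, and none has a readable size. Going by the values given here, the first is a step that the two limits leave unreadable from compound 1 to compound 2. The second is a step that the two limits leave unreadable from compound 1 to compound 3. The third is a step that the two limits leave unreadable from compound 2 to compound 3.

No step size can therefore be carried over to the new group. Compound 3 gives > 5000 nM, a limit, and the expectation rests on that: no readable step is expected in this assay in either direction, and compound 4 is expected to report only a limit as well. The expected change is a step that the limit leaves unreadable from compound 3 to compound 4. The estimated value for compound 4 is 10000 nM, with an expected range from 4000 nM to 25000 nM.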

Compound 4, half-maximal inhibitory concentration: > 5000 nM
Compound 4: a limit, no number; the forecaster's own chance of this, stated with the estimate: 85%; the middle value lies beyond the limit too.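

In this assay compound 4 gives > 5000 nM, a limit of the assay and not a number: the limit of > 5000 nM in this assay, at which 2 of the 4 values shown sit. No step can be read between compound 4 and compound 1, compound 2 or compound 3, as all four are reported only as limits. The compounds shown leave open how these four groups on the sulfonyl sulfur compare, and where any of the compounds would give a measured number.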